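Swapping Methoxy for Trifluoromethyl on a Shared Core

This account rests on a few compounds, and the source may have more. Where it says the series, first, only, none or still open, it means among the compounds named here.

Compound 2 `COc1cccc(C2C(=O)N(C)c3cnc(Nc4ccc(S(N)(=O)=O)cc4)nc3N2C)c1` gives 954 nM in an assay on Sf9 cells for inhibition of serine/threonine-protein kinase 4 (Homo sapiens), read by luminescence and ADP-Glo, with a stated time of 1 h, in the presence of a further agent that is not named here; on this read-out higher numbers stand for weaker inhibition and lower numbers for stronger inhibition. Among the measured compounds shown here, its only measured neighbour is compound 1 `CN1C(=O)C(c2cccc(Cl)c2)N(C)c2nc(Nc3ccc(S(N)(=O)=O)cc3)ncc21`, which in this assay gives 989 nM; the two numbers stand within the scatter of each other, so neither compound can be set apart from the other on this read-out. For the measured compounds named here, the single measured step, a 1.0-fold lower number from compound 1 to compound 2 (0.02 log units; within the scatter), exchanges one small group for another on the same aromatic carbon of the same ring without moving the number beyond the scatter.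

Compound 3 `CN1C(=O)C(c2cccc(C(F)(F)F)c2)N(C)c2nc(Nc3ccc(S(N)(=O)=O)cc3)ncc21` has not yet been measured. Relative to compound 2 it carries trifluoromethyl in place of methoxy on an aromatic carbon. Going by the values given here, the only step that bears on this change is the one from compound 1 to compound 2, which stayed within the scatter; nothing else is known about this position. On that basis a further exchange of the group at this place is expected to change little. Compound 3 is therefore estimated to give 950 nM in this assay, with a likely range of 450 nM to 2000 nM. This estimate means a step of a 1.0-fold lower number from compound 2 to compound 3 (0.00 log units; within the scatter), expected to remain within the scatter.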

Compound 3, half-maximal inhibitory concentration: 2710 nM
Estimate against measurement, compound 3: 2.9-fold (0.46 log units) below; the whole stated range lies below it.
By their numbers in this assay, from the lowest: compounds 2 and 1 (each within the scatter of the next); then compound 3.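

In this assay the aromatic carbon that looked indifferent to its substituent turns out not to accept every group equally: trifluoromethyl in place of methoxy gives a 2.8-fold higher number from compound 2 to compound 3 (0.45 log units; beyond the scatter) and a weaker inhibitor, while trifluoromethyl in place of chloro gives a 2.7-fold higher number from compound 1 to compound 3 (0.44 log units; beyond the scatter) and points the same way. Methoxy and chloro could not be told apart, so the two steps together set trifluoromethyl apart from both of the groups seen before, and the earlier flat result therefore holds for that pair only and not for this position as a whole. Nothing measured here explains why trifluoromethyl differs from the other two groups.

Going by these compounds, three groups on one carbon of one ring give only a narrow view, so it remains open whether an amine, a carboxylic acid or a longer chain such as ethoxy at this place would stay level with methoxy and chloro or fall further away. Also open, on these data alone, is whether the same exchange would carry the same penalty on a different carbon of this ring.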